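Unbound fraction after a sulfonyl swap

The source may report more compounds than this note shows. Statements on the series, on what has been measured and on what is new or still open speak of the compounds shown alone.

Measured in an ADME assay on a cell-free system (plasma, Mus musculus); a higher number here means a larger unbound share of the compound, a lower number a smaller unbound share:
Compound 1 `CCCS(=O)(=O)c1cccc(C#Cc2cc(Cl)ccc2OCC(=O)O)c1`: 0.024
Compound 2 `CN(C)S(=O)(=O)c1ccc(F)c(C#Cc2cc(Cl)ccc2OCC(=O)O)c1`: 0.029

Compound 2 stands at 0.029, within the scatter of compound 1. Compound 3 `CCCS(=O)(=O)c1ccc(F)c(C#Cc2cc(Cl)ccc2OCC(=O)O)c1` carries propyl in place of dimethylamino on a sulfonyl sulfur. Within the data shown here, no measured pair isolates this change. Compound 1 also carries propyl on a sulfonyl sulfur and gives 0.024 in this assay, which suggests little movement. The expected step of a 1.3-fold lower number from compound 2 to compound 3 (0.12 log units; within the scatter) is a slight fall that stays within the scatter. For compound 3 the estimated value is 0.022, with an expected range of 0.012 to 0.04.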

Compound 3, unbound fraction: 0.007
Compound 3: middle estimate off by 3.1-fold (0.50 log units), on the high side, outside the stated range (below it).
By their numbers in this assay, from the lowest: compound 3; then compounds 1 and 2 (each within the scatter of the next).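

In this assay, propyl in place of dimethylamino on a sulfonyl sulfur matters when the fluoro is present, giving a 4.1-fold lower number from compound 2 to compound 3 (0.62 log units; beyond the scatter) and leaving the unbound share clearly smaller. With propyl kept on the sulfonyl sulfur, fluoro in place of hydrogen on an aromatic carbon gives a 3.4-fold lower number from compound 1 to compound 3 (0.54 log units; beyond the scatter) as a second single change, something the two close earlier values did not reveal. Nothing given here explains either step. On these data alone, whether propyl and dimethylamino would also differ without the fluoro stays open. So does whether a longer chain or a cyclic amine on the sulfonyl sulfur would follow compound 3.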